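This account rests on a few compounds, and the source may have more. Where it says the series, first, only, none or still open, it means among the compounds named here.

In a functional assay on IGROV-1 cells (Homo sapiens) for inhibition, read by sulforhodamine B assay, with a stated time of 48 h (on this read-out higher numbers stand for weaker inhibition of growth and lower numbers for stronger inhibition of growth), three compounds have been measured. Compound 1 `O=CN1CCN(c2ccc(Cl)cc2)C1=S` gives 14200 nM, compound 3 `O=CN1CCN(c2cc(Cl)cc(Cl)c2)C1=S` gives 18500 nM, and compound 2 `N#C/C(=C\N1CCN(C(=O)c2ccco2)C1=S)C(N)=O` gives 24000 nM. Compound 2 carries the highest of the three numbers, yet its gap to compound 3 and its gap to compound 1 both lie within the usual scatter, so the three cannot be put in order. Compound 4 `N#C/C(=C\N1CCN(C(=O)c2ccco2)C1=S)C(=O)c1ccccc1` is not yet measured. It differs from compound 2 in one place: phenyl in place of amino on a carbonyl carbon. Within the data shown here, no measured pair shows this change, so no step is known for it. A step of modest size is expected, slightly toward stronger inhibition but possibly none beyond the scatter, giving a 1.6-fold lower number from compound 2 to compound 4 (0.20 log units; within the scatter). Compound 4 is therefore estimated at 15000 nM, within 5000 nM to 50000 nM.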

Compound 4, concentration for 50% growth inhibition: 19400 nM
Compound 4: the middle estimate sits 1.3-fold (0.11 log units) below what was measured; low and high end bracket the measured number.
By their numbers in this assay, from the lowest: compounds 1, 3, 4 and 2 (each within the scatter of the next).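

On the carbonyl carbon of compound 2, replacing amino with phenyl, which turns carbamoyl into benzoyl, gives a 1.2-fold lower number from compound 2 to compound 4 (0.09 log units; within the scatter) in this assay. This first pair at this position shows that removing the amino group's hydrogen-bond donor and adding a six-membered aromatic ring leaves the two compounds indistinguishable. No measurement here offers an explanation for this result.

Going by these compounds, whether a dimethylamino group, a methoxy group or a longer chain on this carbonyl carbon would give a step beyond the scatter remains open. On these data alone, with a single pair, it also remains open whether this change behaves the same way on another core.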